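The source may report more compounds than this note shows. Statements on the series, on what has been measured and on what is new or still open speak of the compounds shown alone.

For the measured compounds named here, compound 1, `Cc1cc(C)c2cc(C#N)c(NCCNC(=O)c3ccncc3)nc2c1`, is the only member of this small set with a number: in an in vitro assay on FRT cells with Cystic fibrosis transmembrane conductance regulator variant F508del (Homo sapiens) as the target, read by fluorescence, with a stated time of 24 h, at 37 degrees C, in the presence of a further agent that is not named here (a lower number here means that less compound is needed, a higher number that more compound is needed for the effect), compound 1 gives 7300 nM. Compound 2, `COc1ccccc1C(=O)NCCCNc1nc2cc(C)cc(C)c2cc1C#N`, is reported in this assay as "not active" (no number reported), so no single figure places it. Compound 3, `Cc1cc(C)c2cc(C#N)c(NCCCNC(=O)c3ccccn3)nc2c1`, differs from compound 2 by pyridin-2-yl in place of 2-methoxyphenyl on a carbonyl carbon. Going by the values given here, with compound 2 lacking a number, no measured step guides the size of this change in this assay; a shift toward measurable, yet weak, potency is expected, with a real chance that only a limit is returned. Compound 3 is estimated at 10000 nM, in the range 2500 nM to 40000 nM.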

Compound 3, half-maximal effective concentration: "not active" (no number reported)
For compound 3 the study gives words and no number; there is nothing to compare the estimate with.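

Compound 2 and compound 3 are both reported as not active in this assay, so no step can be read between them, and nothing measured here offers an explanation. The compounds shown leave open whether pyridin-2-yl in place of 2-methoxyphenyl changes potency at all.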